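Estimating a Fluorobenzyl Analogue of Compound 1

This account rests on a few compounds, and the source may have more. Where it says the series, first, only, none or still open, it means among the compounds named here.

Three compounds sharing one core have been measured in an assay on CHO cells for displacement of a labelled ligand from 5-hydroxytryptamine receptor 1B (Homo sapiens); a higher number here means a weaker inhibitor, a lower number a stronger inhibitor:
Compound 1, `FC1(Cc2ccccc2C(F)(F)F)CCN(CCCc2c[nH]c3ccc(-n4cnnc4)cc23)CC1`, gives 14 nM.
Compound 2, `FC1(CCc2ccccc2)CCN(CCCc2c[nH]c3ccc(-n4cnnc4)cc23)CC1`, gives 49 nM.
Compound 3, `Fc1cccc(CCC2(F)CCN(CCCc3c[nH]c4ccc(-n5cnnc5)cc34)CC2)c1`, gives 22 nM.

Compound 1 has the lowest of the three numbers in this assay. Its gap to compound 3 is within the scatter, while its gap to compound 2 lies beyond it. Compound 4, `Fc1ccc(CCC2(F)CCN(CCCc3c[nH]c4ccc(-n5cnnc5)cc34)CC2)cc1`, has not been measured; it differs from compound 1 by 4-fluorobenzyl in place of 2-(trifluoromethyl)phenyl on a saturated chain carbon bound to a saturated ring carbon. Among the measured compounds shown here, two measured steps bear on this change. Replacing the same group with a benzyl gave a 3.5-fold higher number from compound 1 to compound 2 (0.54 log units; beyond the scatter), and replacing it with a 3-fluorobenzyl gave a 1.6-fold higher number from compound 1 to compound 3 (0.20 log units; within the scatter); the fluoro in place of hydrogen on an aromatic carbon that separates those two cases gave a 2.2-fold lower number from compound 2 to compound 3 (0.35 log units; beyond the scatter). For the measured compounds named here, the 4-fluorobenzyl of compound 4 carries a fluorine on its ring as compound 3 does, but no measured step covers this particular group, so the outcome could resemble either compound 2 or compound 3. Compound 4 is therefore expected to give a modestly higher number than compound 1, about a 2.1-fold higher number from compound 1 to compound 4 (0.33 log units; beyond the scatter). The estimate for compound 4 in this assay is 30 nM, with a range from 12 nM to 75 nM.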

Compound 4, half-maximal inhibitory concentration: 25 nM
For compound 4 the middle estimate is 1.2-fold (0.08 log units) above the measured one; measured number inside the range.
By their numbers in this assay, from the lowest: compounds 1, 3, 4 and 2 (each within the scatter of the next, the first and the last beyond it).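

In this assay the 4-fluorophenyl in place of 3-fluorophenyl on a saturated chain carbon, two bonds along the chain from a saturated ring carbon, gives a 1.1-fold higher number from compound 3 to compound 4 (0.06 log units; within the scatter) and so does not separate these two fluorine-bearing groups. Fluoro in place of hydrogen on an aromatic carbon now gives a 2.0-fold lower number from compound 2 to compound 4 (0.29 log units; within the scatter) while the same kind of change to compound 3 gave a 2.2-fold lower number from compound 2 to compound 3 (0.35 log units; beyond the scatter) so the step from compound 2 passes beyond the scatter for the 3-fluorophenyl group but not for the 4-fluorophenyl group. Among the compounds shown here, the 4-fluorobenzyl in place of 2-(trifluoromethyl)phenyl gives a 1.8-fold higher number from compound 1 to compound 4 (0.25 log units; within the scatter) which places compound 4 with compound 3 within the scatter of compound 1, and leaves compound 2 as the only compound beyond the scatter of compound 1.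

No evidence is available to account for any of these steps. The compounds shown leave open how a 2-fluorophenyl group, a chloro or methoxy on the same aromatic ring, or a longer chain would read in this assay and what hydrogen in place of the fluoro on the saturated ring carbon would do.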